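Sulfamoyl to Methylsulfonyl on a Shared Aminothiazole Scaffold

A few compounds are considered here, and "the series" means these few. Any claim that something is new, unique, unknown or untested is made for them only; others in the source may bear on it.

Compound 1 `Cc1ccc2nc(Nc3nc(Nc4ccc(S(N)(=O)=O)cc4)ncc3F)sc2c1`: 4960 nM
Compound 2 `Cc1ccc2nc(Nc3nc(Nc4ccc(S(C)(=O)=O)cc4)ncc3F)sc2c1`: > 50000 nM, a limit of the assay
Compound 3 `COc1ccc2nc(Nc3ccnc(Nc4ccc(S(N)(=O)=O)cc4)n3)sc2c1`: 3030 nM

Of the compounds shown here, three have been measured in a functional assay on PC-3 cells (Homo sapiens) for antiproliferative activity, read by MTT assay, with a stated time of 48 h; a higher number here means a weaker inhibitor, a lower number a stronger inhibitor. Compound 1 gives 4960 nM. Compound 2 reaches only a limit of the assay, > 50000 nM. Compound 3 gives 3030 nM, within the scatter of compound 1, so no order between these two is claimed. The difference between the core of compound 1 and the core of compound 3 is not broken down here.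

Compound 1 and compound 2 differ in one place: methyl in place of amino on a sulfonyl sulfur. This change produced an at least 10-fold higher number from compound 1 to compound 2 (1.00 log units; beyond the scatter). The size of the step is bounded only on one side, since compound 2 sits at the limit of > 50000 nM in this assay, at which 1 of the 3 values shown sits.

Compound 4 `COc1ccc2nc(Nc3ccnc(Nc4ccc(S(C)(=O)=O)cc4)n3)sc2c1` has not yet been measured. It differs from compound 3 by methyl in place of amino on a sulfonyl sulfur, the same change at the same place as from compound 1 to compound 2. On that basis compound 4 is expected to be a weaker inhibitor than compound 3, with an expected step of a 13-fold higher number from compound 3 to compound 4 (1.12 log units; beyond the scatter), resting on the step of an at least 10-fold higher number from compound 1 to compound 2 (1.00 log units; beyond the scatter). Compound 4 is accordingly estimated at 40000 nM, with a range from 15000 nM to 120000 nM, and a real chance that this assay returns only a limit.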

Compound 4, half-maximal inhibitory concentration: 2700 nM
For compound 4 the middle estimate is 15-fold (1.17 log units) above the measured one; measured number outside the range, below it.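

In this assay, putting methyl in place of amino on the sulfonyl sulfur gave a 1.1-fold lower number from compound 3 to compound 4 (0.05 log units; within the scatter), so on the core of compound 3 this change left the number within the scatter. The large step seen on the core of compound 1 therefore did not carry over to the core of compound 3, and the outcome of this change in the series depended on the core it was made on: the same change on two cores in this assay, an at least 10-fold higher number (1.00 log units; beyond the scatter) from compound 1 to compound 2 and a 1.1-fold lower number (0.05 log units; within the scatter) from compound 3 to compound 4, at least 11-fold (1.05 log units) apart, beyond the scatter of two such steps. This does not show which feature of the two cores accounts for the gap, since the cores differ from each other and no pair shown separates their differences, and the size of the earlier step is known only from one side, as its second compound sits at a limit: the limit of > 50000 nM in this assay, at which 1 of the 4 values shown sits.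

With only two matched pairs, the compounds shown leave open whether a further core would follow the pattern of compound 1 and compound 2 or that of compound 3 and compound 4. They also leave open how other groups on the sulfonyl sulfur, such as an ethyl chain or a dimethylamino group, would read in this assay on either core.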